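This account rests on a few compounds, and the source may have more. Where it says the series, first, only, none or still open, it means among the compounds named here.

In a functional assay on U-937 cells (Homo sapiens) for antagonist activity, read by calcium flux (a lower number here means a stronger inhibitor, a higher number a weaker inhibitor), three compounds have been measured:

compound 1 `COc1ccc(CCCCCCCCOc2ccc(CSc3cccc(N)c3)nc2/C=C/C(=O)O)cc1` gives 54 nM
compound 2 `COc1ccc(CCCCCCCCOc2ccc(CSc3cccc(OC)c3)nc2/C=C/C(=O)O)cc1` gives 290 nM
compound 3 `COc1ccc(CCCCCCCCOc2ccc(CSc3ccccc3)nc2/C=C/C(=O)O)cc1` gives 110 nM

Compound 1 has the lowest number of the three: a 2.0-fold higher number from compound 1 to compound 3 (0.31 log units; beyond the scatter) and a 5.4-fold higher number from compound 1 to compound 2 (0.73 log units; beyond the scatter). The cores of compound 2 and compound 1 differ by amino in place of methoxy on an aromatic carbon.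

Compound 4 `Nc1cccc(SCc2ccc(OCCCCCCCCc3ccccc3)c(/C=C/C(=O)O)n2)c1` is not yet measured. It differs from compound 1 by hydrogen in place of methoxy on an aromatic carbon. The same kind of change has been made once before, from compound 2 to compound 3 (hydrogen in place of methoxy on an aromatic carbon), and there it gave a 2.6-fold lower number from compound 2 to compound 3 (0.42 log units; beyond the scatter). The place is not identical: in the earlier pair the group sat meta to a large group, while in compound 4 it sits para to a large group, on a different ring of the molecule.

Because compound 1 gives 54 nM and the earlier step was a 2.6-fold lower number from compound 2 to compound 3 (0.42 log units; beyond the scatter), a step of a 1.2-fold lower number from compound 1 to compound 4 (0.08 log units; within the scatter) is expected for compound 4, with wide uncertainty since the place differs. Compound 4 is estimated at 45 nM, expected between 18 nM and 120 nM.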

Compound 4, half-maximal inhibitory concentration: 60 nM
Beside the measured number, compound 4's estimate is 1.3-fold (0.12 log units) below it; low and high end bracket the measured number.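

In this assay, hydrogen in place of methoxy on the 4-methoxyphenyl group gives a 1.1-fold higher number from compound 1 to compound 4 (0.05 log units; within the scatter), so on the core of compound 1 this change cannot be told apart from the scatter. The same kind of change at a different place, on a different ring, gave a result of a different size: the same change on two cores in this assay, a 2.6-fold lower number (0.42 log units; beyond the scatter) from compound 2 to compound 3 and a 1.1-fold higher number (0.05 log units; within the scatter) from compound 1 to compound 4, 2.9-fold (0.47 log units) apart, beyond the scatter of two such steps. So the step seen at one place did not carry over to the other, but two pairs cannot show whether the ring, the place or the rest of the core accounts for the gap.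

The compounds shown leave open what a chloro or hydroxyl group would do in place of that methoxy. They also leave open whether a shorter or longer chain would alter the picture.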